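The source may hold more compounds than are shown below. What is called first, only, known or untested is meant among the compounds shown, and "the series" means these compounds.

Measured in a functional assay on MGC-803 cells (Homo sapiens) for antiproliferative activity, read by MTT assay, with a stated time of 48 h; on this read-out higher numbers stand for weaker inhibition and lower numbers for stronger inhibition:
- compound 1 `COc1ccc(CN(C(=O)CSc2nc3ccccc3s2)c2cc(OC)c(OC)c(OC)c2)cc1N=[N+]=[N-]`: 187 nM
- compound 2 `COc1ccc(CN(C(=O)CSc2nc3ccccc3s2)c2cc(OC)c(OC)c(OC)c2)cc1[N+](=O)[O-]`: 682 nM

Of these two results, compound 2 has the higher number at 682 nM, which means the weaker inhibition. The next molecule, compound 3 `COc1cc(CN(C(=O)CSc2nc3ccccc3s2)c2cc(OC)c(OC)c(OC)c2)cc(OC)c1OC`, has not yet been measured. It keeps the shared core of compound 2 and differs in one group: 3,4,5-trimethoxyphenyl in place of 4-methoxy-3-nitrophenyl on a saturated chain carbon bound to an amide-type nitrogen.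

Among the measured compounds shown here, only one measured step bears on this change: a 3.6-fold higher number from compound 1 to compound 2 (0.56 log units; beyond the scatter). That modest step, beyond the scatter, involved a swap on the same aromatic ring, with nitro in place of azido. It shows that a change on this ring can move the number, but a single step cannot show which way a different ring will go. In compound 3 the nitro group is gone altogether, so a step of similar modest size is expected in this assay, with a tentative lean towards a higher number. The expected step is a 2.2-fold higher number from compound 2 to compound 3 (0.34 log units; beyond the scatter). For compound 3, the estimate is 1500 nM, with an expected range of 400 nM to 5500 nM.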

Compound 3, half-maximal inhibitory concentration: 45700 nM
The estimate for compound 3 lay 30-fold (1.48 log units) below the measured number; the measured number lies above the stated range.
By their numbers in this assay, from the lowest: compound 1; then compound 2; then compound 3.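

In this assay the aromatic ring on the saturated chain carbon bound to an amide-type nitrogen proves far more sensitive than the swap of azido for nitro could show: putting 3,4,5-trimethoxyphenyl in place of 4-methoxy-3-nitrophenyl gives a 67-fold higher number from compound 2 to compound 3 (1.83 log units; beyond the scatter) and marks a large loss of inhibition. Set against the azido ring, the same kind of change gives a 240-fold higher number from compound 1 to compound 3 (2.39 log units; beyond the scatter) and is the widest gap among these three compounds, so the two rings that carry a nitrogen-containing group both stand well ahead of the ring with three methoxy groups. Nothing measured here accounts for this drop.

This one change removes the nitro group and adds methoxy groups together, so the compounds shown cannot separate what losing the one contributes from what gaining the others contributes. On these data alone, it also remains open how the number would move with a simple amine or a carboxylic acid in place of the nitro or azido group on this ring.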